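The source may report more compounds than this note shows. Statements on the series, on what has been measured and on what is new or still open speak of the compounds shown alone.

Of the compounds shown here, three that share one core have been measured in a functional assay on HeLa cells (Homo sapiens) for antiproliferative activity, read by MTT assay, with a stated time of 72 h; a higher number here means a weaker inhibitor, a lower number a stronger inhibitor. Compound 1 `Cc1ccc(-c2cn(C/C=C3\OC(=O)C(OCc4ccccc4)=C3OCc3ccccc3)nn2)cc1` gives 7480 nM. Compound 2 `O=C1O[C@H]([C@@H](O)Cn2cc(CCO)nn2)C(OCc2ccccc2)=C1OCc1ccccc1` gives 68800 nM, the higher of the two numbers, with compound 1 the nearer of the pair and the gap between them beyond the usual scatter. Compound 3 `O=C1O/C(=C\Cn2cc(-c3cc(C(F)(F)F)cc(C(F)(F)F)c3)nn2)C(OCc2ccccc2)=C1OCc1ccccc1` sits at the edge of the assay, > 100000 nM, which is a limit and not a number (the limit of > 100000 nM in this assay, at which 1 of the 3 values shown sits). Compound 4 `CCCCCCCCCCc1cn(C[C@H](O)[C@H]2OC(=O)C(OCc3ccccc3)=C2OCc2ccccc2)nn1` has not yet been measured in this assay. It differs from compound 2 in one place: octyl in place of hydroxy on a saturated chain carbon, two bonds along the chain from an aromatic carbon. Among the compounds with values here, no measured pair shows a change of this kind, so the expectation rests on compound 2 alone. For compound 4 a lower number is expected, beyond the scatter, as a 4.6-fold lower number from compound 2 to compound 4 (0.66 log units; beyond the scatter). Compound 4 is therefore estimated at 15000 nM, within 3000 nM to 70000 nM.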

Compound 4, half-maximal inhibitory concentration: 22900 nM
Beside the measured number, compound 4's estimate is 1.5-fold (0.18 log units) below it; the range from low to high includes it.
By their numbers in this assay, from the lowest: compound 1; then compound 4; then compound 2. At a limit, above all of these: compound 3.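

In this assay, within the data shown here, replacing hydroxy with octyl on a saturated chain carbon, two bonds along the chain from an aromatic carbon, gives a 3.0-fold lower number from compound 2 to compound 4 (0.48 log units; beyond the scatter) and so a first reading of change at this position. The step shows that the position tolerates the larger octyl, with a modest fall in the number rather than a loss of activity. Nothing measured here accounts for the size of this step. Still open, from the compounds shown here alone, is whether a longer chain would lower the number further, and how an amine or a carboxylic acid at this position would read.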